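The source may hold more compounds than are shown below. What is called first, only, known or untested is meant among the compounds shown, and "the series" means these compounds.

Compound 1 `COc1ccc2[nH]c(C(=O)N3CC(=O)N(Cc4ccccc4)[C@@H](COc4ccccc4)C3)cc2c1` gives 12200 nM
Compound 2 `COc1ccc2[nH]c(C(=O)N3CC(=O)N(Cc4ccccc4)[C@@H](CN4CCCCC4)C3)cc2c1` gives > 25000 nM
Compound 3 `COc1ccc2[nH]c(C(=O)N3CC(=O)N(Cc4ccccc4)[C@@H](CN4CCN(c5ccccn5)CC4)C3)cc2c1` gives 30200 nM

These readings come from a physicochemical assay for solubility, read by spectrophotometry, in phosphate buffer, with a stated time of 2 h, at pH 7.4 (on this read-out lower numbers stand for lower solubility and higher numbers for higher solubility), and the three compounds differ in a single group. For compound 2 the reading > 25000 nM is a limit of the assay and not a number. Of the two true numbers, the higher belongs to compound 3 at 30200 nM and the lower to compound 1 at 12200 nM by a margin beyond the scatter.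

Compound 4 `COc1ccc2[nH]c(C(=O)N3CC(=O)N(Cc4ccccc4)[C@@H](CN4CC5CCCC5C4)C3)cc2c1` differs from compound 3 in one place: a group of 8 heavy atoms (7 carbon, 1 nitrogen; one five-membered non-aromatic ring of carbon only, one five-membered non-aromatic ring with 1 hetero atom) in place of a group of 12 heavy atoms (9 carbon, 3 nitrogen; one six-membered non-aromatic ring with 2 hetero atoms, one six-membered aromatic ring with 1 hetero atom), on a saturated chain carbon bound to a saturated ring carbon while the rest stays the same. In this assay two measured steps changed that place, both starting from phenoxy: an at least 2.0-fold higher number from compound 1 to compound 2 (0.31 log units; beyond the scatter) and a 2.5-fold higher number from compound 1 to compound 3 (0.39 log units; beyond the scatter) were both upward and modest. The remaining step, a step that the limit leaves unreadable from compound 2 to compound 3 gives no size to work with. Compound 4 also lacks phenoxy, so, like compound 3 at 30200 nM it is expected to stay high, with no step beyond the scatter. The expected change is a 1.2-fold lower number from compound 3 to compound 4 (0.08 log units; within the scatter) in this estimate. The estimated value for compound 4 is 25000 nM with an expected range from 12000 nM to 45000 nM in this read-out.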

Compound 4, solubility: 20700 nM
For compound 4 the middle estimate is 1.2-fold (0.08 log units) above the measured one, within the range that was stated.
By their numbers in this assay, from the lowest: compounds 1, 4 and 3 (each within the scatter of the next, the first and the last beyond it).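

In this assay, the new group on a saturated chain carbon bound to a saturated ring carbon has fewer heavy atoms than 4-(pyridin-2-yl)piperazin-1-yl and no aromatic ring, yet the swap gives a 1.5-fold lower number from compound 3 to compound 4 (0.16 log units; within the scatter). Set against phenoxy, the same group gives a 1.7-fold higher number from compound 1 to compound 4 (0.23 log units; within the scatter), so unlike the group in compound 3 it does not clear the scatter from compound 1. With piperidin-1-yl the reading is a limit and not a number, so an at least 1.2-fold lower number from compound 2 to compound 4 (0.08 log units; that floor lies within the scatter) gives only a floor: the limit of > 25000 nM in this assay, at which 1 of the 4 values shown sits.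

Phenoxy is the only group shown without a nitrogen, and compound 1 lies within the scatter of compound 4, so what that nitrogen contributes stays unsettled. Also open, as far as these compounds go, is how a carboxylic acid or an open-chain amine such as diethylamino would read at this place.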